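Ester variation in the series: expectation for compound 4

The source may report more compounds than this note shows. Statements on the series, on what has been measured and on what is new or still open speak of the compounds shown alone.

Measured so far in an assay on membranes from CHO cells for displacement of a labelled ligand from adenosine receptor A1 (Homo sapiens), read by scintillation counting, with a stated time of 60 min, tested at 1 uM; on this read-out higher numbers stand for more inhibition at the one concentration tested (going by the name of the read-out) and lower numbers for less inhibition:

compound 1, `CC1=C(C(=O)OCc2ccccc2)C(c2ccsc2)NC(=O)N1`: 57%
compound 2, `CCCC(=O)C1=C(C)NC(=O)NC1c1ccsc1`: 6%
compound 3, `CCC(CC)OC(=O)C1=C(C)NC(=O)NC1c1ccsc1`: 22%

Compound 3 stands second highest of the three numbers in this assay: it lies a number 35 percentage points lower from compound 1 to compound 3 (beyond the scatter) and a number 16 percentage points higher from compound 2 to compound 3 (beyond the scatter).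

Compound 4, `CC1=C(C(=O)OCC2CC2)C(c2ccsc2)NC(=O)N1`, is not yet measured. It differs from compound 3 by cyclopropylmethyl in place of pentan-3-yl on an oxygen next to a carbonyl group.

The step that bears on this change is the one on the same oxygen, a number 35 percentage points lower from compound 1 to compound 3 (beyond the scatter), which shows the group on this oxygen moves the read-out strongly; the step of a number 16 percentage points higher from compound 2 to compound 3 (beyond the scatter) concerns the carbonyl carbon and is less directly relevant. Within the data shown here, no measured pair shows cyclopropylmethyl against pentan-3-yl, so the direction is open; the expectation is a step of about no change at the digits printed from compound 3 to compound 4 (within the scatter), within the scatter, in this assay.

Compound 4 is therefore estimated at 22% in this assay, with a range of 6% to 42%.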

Compound 4, a percentage reported as inhibition, at one concentration (the size of the read-out at that concentration, not a potency): 39%
Compound 4: the middle estimate sits 17 percentage points below what was measured, and the stated range covers the measured number.
By their numbers in this assay, from the lowest: compound 2; then compound 3; then compound 4; then compound 1.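

In this assay the group on this oxygen shifts the read-out even between two all-carbon groups without an aromatic ring: cyclopropylmethyl in place of pentan-3-yl gives a number 17 percentage points higher from compound 3 to compound 4 (beyond the scatter) on this change. With the saturated chain carbon kept, cyclopropyl in place of phenyl gives a number 18 percentage points lower from compound 1 to compound 4 (beyond the scatter) and so costs less than the change from benzyl to pentan-3-yl, while cyclopropylmethoxy in place of propyl on the carbonyl carbon gives a number 33 percentage points higher from compound 2 to compound 4 (beyond the scatter) and exceeds the step seen with (pentan-3-yl)oxy. Nothing available explains these steps.

From the compounds shown here alone, whether the three-membered ring or the loss of pentan-3-yl itself carries the gain remains open, as a plain ethyl or isobutyl group on this oxygen would be needed to separate them. Also open, going by these compounds, is how a longer chain, or an amine on the chain, would read at this oxygen.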